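Lengthening the hydroxamate linker on a shared core

This account rests on a few compounds, and the source may have more. Where it says the series, first, only, none or still open, it means among the compounds named here.

Measured so far:
compound 1 `CNC(=O)CCCCCCCn1nc(-c2ccc3oc(N)nc3c2)c2c(N)ncnc21`, 3150 nM
compound 2 `Nc1ncnc2c1c(-c1cnc3[nH]ccc3c1)nn2CCCC(=O)NO`, > 150000 nM
compound 3 `Nc1nc2cc(-c3nn(CCCCCC(=O)NO)c4ncnc(N)c34)ccc2o1`, 21500 nM

In a functional assay on HCT-116 cells (Homo sapiens) for inhibition, read by MTT assay, with a stated time of 72 h (a higher number here means a weaker inhibitor, a lower number a stronger inhibitor), compound 3 stands highest of the two numbers given; compound 2 reports only a limit, (the limit of > 150000 nM in this assay, at which 1 of the 3 values shown sits). Within the data shown here, the one measured step nearby is a 6.8-fold higher number from compound 1 to compound 3 (0.83 log units; beyond the scatter), a modest weakening. Compound 4 `Nc1nc2cc(-c3nn(CCCCCCCCCC(=O)NO)c4ncnc(N)c34)ccc2o1` keeps the core of compound 3 and differs by 4-(hydroxycarbamoyl)butyl in place of hydroxycarbamoyl on a saturated chain carbon, five bonds along the chain from an aromatic nitrogen. Among the measured compounds shown here, no measured step changes only the chain length, so the bearing of that single step is indirect: it shows the hydroxycarbamoyl end at the shorter distance sits weaker than the longer carbamoyl chain of compound 1. Compound 4 is therefore expected to turn out somewhat stronger, an estimated 4.3-fold lower number from compound 3 to compound 4 (0.63 log units; beyond the scatter). The expected value for compound 4 is 5000 nM, within 1500 nM to 30000 nM.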

Compound 4, half-maximal inhibitory concentration: 23100 nM
Compound 4: the middle estimate sits 4.6-fold (0.66 log units) below what was measured; low and high end bracket the measured number.
By their numbers in this assay, from the lowest: compound 1; then compounds 3 and 4 (each within the scatter of the next). At a limit, above all of these: compound 2.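

In this assay, the longer chain on the shared core gives a 1.1-fold higher number from compound 3 to compound 4 (0.03 log units; within the scatter) and so, at these two lengths, chain length does not separate the two hydroxycarbamoyl compounds. Seven bonds along the chain from an aromatic nitrogen, 2-(hydroxycarbamoyl)ethyl in place of methylcarbamoyl gives a 7.3-fold higher number from compound 1 to compound 4 (0.87 log units; beyond the scatter) and so the methylcarbamoyl end of compound 1 now stands apart at a matched chain position, not only at a shorter one.

From the compounds shown here alone, how a carboxylic acid or a primary amide at the chain end would read stays open. The compounds shown offer no cause for either step.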